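This account rests on a few compounds, and the source may have more. Where it says the series, first, only, none or still open, it means among the compounds named here.

Compound 1 `C=C1[C@H](OC(C)=O)[C@@H](OC(C)=O)[C@@H](OC(C)=O)C(C)(C)/C=C/[C@H](C)[C@H](OC(=O)c2ccccc2)[C@@]2(O)C[C@@](C)(OC(=O)c3ccncc3)[C@H](OC(C)=O)[C@@H]2[C@H]1OCC(C)C`, a limit: > 100000 nM
Compound 2 `C=C1[C@H](OC(C)=O)[C@@H](OC(C)=O)[C@@H](OC(C)=O)C(C)(C)/C=C/[C@H](C)[C@H]2O[C@]3(C)C[C@@]2(OC(=O)c2ccccc2)[C@H]([C@H]3OC(C)=O)[C@H]1OCC(C)C`, a limit: > 100000 nM

In a functional assay on NCI/ADR-RES cells (Homo sapiens) for antiproliferative activity, read by MTT assay, with a stated time of 48 h (on this read-out higher numbers stand for weaker inhibition and lower numbers for stronger inhibition), compound 2 gives no number, only the limit > 100000 nM. Compound 1 gives no number either, so both measured compounds stand at the same point: the limit of > 100000 nM in this assay, at which 2 of the 2 values shown sit. Among the compounds with values here, there is no measured step to show how a change in structure moves this read-out, and the two limits do not rank the compounds.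

Compound 3 `C=C1[C@H](OC(C)=O)[C@@H](OC(=O)c2cccc(C)c2)[C@@H](OC(C)=O)C(C)(C)/C=C/[C@H](C)[C@H]2O[C@]3(C)C[C@@]2(OC(=O)c2ccccc2)[C@H]([C@H]3OC(C)=O)[C@H]1OCC(C)C` differs from compound 2 in one place. It carries 3-methylphenyl in place of methyl on a carbonyl carbon, which turns an acetoxy into a ((3-methylphenyl)carbonyl)oxy (3-methylphenyl in place of methyl on a carbonyl carbon). The rest of the structure is unchanged.

The limit of compound 2 at > 100000 nM leaves room to detect movement only toward stronger inhibition. A small step in that direction is therefore expected in this assay, and compound 3 may well return only a limit again. The estimated step is an at least 1.6-fold lower number from compound 2 to compound 3 (0.22 log units; that floor lies within the scatter). Compound 3 is expected at 60000 nM, with an estimated range of 20000 nM to 100000 nM.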

Compound 3, half-maximal inhibitory concentration: > 100000 nM
Compound 3: a limit, no number (the forecaster's own chance of this, stated with the estimate: 55%); middle value at least 1.6-fold (0.22 log units) from the limit.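

Compound 3 also returns only a limit, > 100000 nM, so the step between compound 2 and compound 3 cannot be read. The three compounds share a single point: the limit of > 100000 nM in this assay, at which 3 of the 3 values shown sit. The compounds shown leave open whether replacing methyl with 3-methylphenyl on that carbonyl carbon changes the inhibition at all, and in which direction.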